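A Methylsulfanyl Side Chain Follows a Hydroxyethyl One

The source may report more compounds than this note shows. Statements on the series, on what has been measured and on what is new or still open speak of the compounds shown alone.

The three measured compounds in a functional assay on the whole organism (Tail, strain ICR) with Mus musculus as the target, in the tail flick test, with a stated time of 60 min, at a dose of 25 umol/kg by the oral route; on this read-out lower numbers stand for a weaker effect and higher numbers for a stronger effect at the one dose given:
compound 1, `N=C(N)NCCC[C@H](NC(=O)CN(c1nc(Cl)nc2[nH]cnc12)C1CC1)C(=O)O`, gives 51%;
compound 2, `O=C(O)CC[C@H](NC(=O)CN(c1nc(Cl)nc2[nH]cnc12)C1CC1)C(=O)O`, gives 33.3%;
compound 3, `C[C@@H](O)[C@H](NC(=O)CN(c1nc(Cl)nc2[nH]cnc12)C1CC1)C(=O)O`, gives 30.1%.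

Compound 3 holds the lowest of the three numbers. Its nearest neighbour is compound 2, and that pair is separated by a number 3.2 percentage points lower from compound 2 to compound 3 (within the scatter), a gap within the scatter. Its furthest neighbour is compound 1, separated by a number 20.9 percentage points lower from compound 1 to compound 3 (beyond the scatter), a gap beyond the scatter.

Compound 4, `CSCC[C@H](NC(=O)CN(c1nc(Cl)nc2[nH]cnc12)C1CC1)C(=O)O`, has not yet been measured in this assay. It differs from compound 3 in one place: 2-(methylsulfanyl)ethyl in place of 1-hydroxyethyl on a saturated chain carbon bound to an amide-type nitrogen and a carbonyl carbon.

Two of the measured steps alter the same saturated chain carbon and therefore bear on this change. One of them, a number 20.9 percentage points lower from compound 1 to compound 3 (beyond the scatter), was modest but beyond the scatter; the other, a number 3.2 percentage points lower from compound 2 to compound 3 (within the scatter), stayed within it. Neither introduces a 2-(methylsulfanyl)ethyl group, so the data give no direct guide to its effect, and the prudent expectation is a step within the scatter, or at most a modest one upward. For compound 4 the expected step is a number 7.9 percentage points higher from compound 3 to compound 4 (within the scatter). Compound 4 is thus estimated to give 38% in this assay, with a range from 22% to 56%.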

Compound 4, a percentage reported as activity, at one dose (the size of the read-out at that dose, not a potency): 22.8%
For compound 4 the middle estimate is 15.2 percentage points above the measured one; measured number inside the range.
By their numbers in this assay, from the lowest: compounds 4, 3 and 2 (each within the scatter of the next, the first and the last beyond it); then compound 1.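

In this assay the exchange of 1-hydroxyethyl for 2-(methylsulfanyl)ethyl on the saturated chain carbon bound to an amide-type nitrogen and a carbonyl carbon gives a number 7.3 percentage points lower from compound 3 to compound 4 (within the scatter) so these two side chains cannot be told apart, and a chain without a hydroxyl or a carboxy group holds the number no better than one with either. For the compounds shown here, the methylsulfanyl end does stand apart from the carboxy end, with a number 10.5 percentage points lower from compound 2 to compound 4 (beyond the scatter) as the first step beyond the scatter among the three side chains that lack the nitrogen-rich group of compound 1, while a number 28.2 percentage points lower from compound 1 to compound 4 (beyond the scatter) is the widest step in the set and leaves compound 1 alone at the top. Nothing shown here accounts for these differences between side chains.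

As far as these compounds go, whether a simple amine at the end of the chain would keep the number of compound 1, or whether the nitrogen-rich group needs its full length, stays open. So does the fate of a phenyl ring or a plain butyl chain on the same carbon, and whether either would sit with compound 4 or rise towards compound 1.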